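Extending the Side Chain on the Weaker Configuration

A few compounds are considered here, and "the series" means these few. Any claim that something is new, unique, unknown or untested is made for them only; others in the source may bear on it.

Compound 1 `CCCCCCOC(C)(C)[C@H](O)COc1ccc(C(CC)(CC)c2ccc(OC[C@@H](O)CO)c(C)c2)cc1C` is tested in an assay on HEK293 cells for agonist activity at vitamin D3 receptor (Homo sapiens), read by a beta-galactosidase reporter; a lower number here means that less compound is needed, a higher number that more compound is needed for the effect. In this assay compound 1 reaches only the limit > 10000 nM, so no number is known for it. Compound 2 `CCCCCCOC(C)(C)[C@@H](O)COc1ccc(C(CC)(CC)c2ccc(OC[C@@H](O)CO)c(C)c2)cc1C` gives 1500 nM in this assay, and the step of an at least 6.6-fold lower number from compound 1 to compound 2 (0.82 log units; beyond the scatter) rests on (the fact that compounds 1 and 2 differ only in the configuration as drawn). Compound 3 `CCC(CC)(c1ccc(OC[C@@H](O)CO)c(C)c1)c1ccc(OC[C@@H](O)C(C)(C)OCCCCCCCCO)c(C)c1` keeps the configuration of compound 1 and carries 2-hydroxyethyl in place of hydrogen on a saturated chain carbon, six bonds along the chain from an oxygen on a saturated carbon. For the measured compounds named here, no measured step tests such a chain extension. The estimated step is a step that the limit leaves unreadable from compound 1 to compound 3, so compound 3 is expected to remain weak. The estimate for compound 3 is 15000 nM, between 3000 nM and 60000 nM, in this assay.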

Compound 3, half-maximal effective concentration: > 3000 nM
Compound 3: only a limit was reported; the forecaster's own chance of this, stated with the estimate: 60%; the middle value lies beyond the limit too.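

In this assay compound 1 gives only the limit > 10000 nM. Compound 3 gives only the limit > 3000 nM, so the step between the two cannot be read. On these data alone, whether the 2-hydroxyethyl extension changes the effect at all stays open.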